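This account rests on a few compounds, and the source may have more. Where it says the series, first, only, none or still open, it means among the compounds named here.

Going by the values given here, compound 1 `CCCC(=O)N1CC2CC(C1)N2` is the stronger of the two compounds measured so far. In an assay on SH-EP1 cells for agonist activity at Neuronal acetylcholine receptor; alpha4/beta2 (Homo sapiens), read by FLIPR and calcium flux (on this read-out higher numbers stand for larger maximal responses and lower numbers for smaller maximal responses), compound 1 gives 110%, the highest of the two numbers. Its nearest neighbour is compound 2 `O=C(CC1C=CCC1)N1CC2CC(C1)N2`, which in this assay reaches 94%. Among the compounds with values here, the one measured step, a number 16 percentage points lower from compound 1 to compound 2 (beyond the scatter), goes with cyclopent-2-en-1-yl entering in place of ethyl on a saturated chain carbon bound to the carbonyl carbon, so a ring in place of a short chain cost a modest amount of maximal response.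

Compound 3 `O=C([C@H]1C[C@H]1F)N1CC2CC(C1)N2` is not yet measured. It differs from compound 1 as follows: 2-fluorocyclopropyl in place of propyl on a carbonyl carbon. Here too a chain leaves and a small ring enters, now with a fluorine on the ring, and the ring sits directly on the carbonyl carbon rather than one carbon further along the chain. Within the data shown here, the step from compound 1 to compound 2 is the only guide, and it points to a small loss or to no change beyond the scatter.

Compound 3 is therefore expected to give about 100% in this assay, within roughly 80% to 120%. The estimated step is a number 10 percentage points lower from compound 1 to compound 3 (within the scatter), a modest drop at most.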

Compound 3, largest response reached (Emax), in percent of the reference or control that the assay uses: 110%
The estimate for compound 3 lay 10 percentage points below the measured number, within the range that was stated.
By their numbers in this assay, from the lowest: compound 2; then compounds 1 and 3 (each within the scatter of the next).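

The step of no change at the digits printed from compound 1 to compound 3 (within the scatter) shows that on this carbonyl carbon, propyl can be replaced by 2-fluorocyclopropyl, which brings a three-membered ring, a fluorine and two defined stereocentres, with no loss of maximal response in this assay. The earlier step of a number 16 percentage points lower from compound 1 to compound 2 (beyond the scatter) could have suggested that a ring in place of a short chain costs response, but compound 3 goes against that as a general rule, and the cost seen with compound 2 belongs to that one change on a saturated chain carbon. No measurement is available here that explains why the two ring changes give different outcomes.

From the compounds shown here alone, the change to compound 3 brings in the ring and the fluorine together, so the part played by each remains open, and plain cyclopropyl on the same carbonyl carbon would separate them, while the mirror-image form of the 2-fluorocyclopropyl group would test whether the arrangement of its stereocentres matters. Going by these compounds, how this position responds to something quite different, such as a phenyl ring or a chain ending in an amine, also remains unknown.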